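Ring replacement at compound 2

The source may report more compounds than this note shows. Statements on the series, on what has been measured and on what is new or still open speak of the compounds shown alone.

In a functional assay on DU-145 cells (Homo sapiens) for inhibition, read by trypan blue exclusion, with a stated time of 96 h (a higher number here means a weaker inhibitor of growth, a lower number a stronger inhibitor of growth), compound 1 `COc1ccc(/C=C(\C(=O)c2ccc(Br)cc2)S(=O)(=O)c2ccc(Br)cc2)cc1` gives 25000 nM and compound 2 `COc1ccc(/C=C(\C(=O)c2ccc(Br)cc2)S(=O)(=O)c2ccc(Br)cc2)c(F)c1` gives 10000 nM, the lower of the two numbers. Going by the values given here, the only measured step is a 2.5-fold lower number from compound 1 to compound 2 (0.40 log units; beyond the scatter), a modest one, from fluoro in place of hydrogen on an aromatic carbon of the ring that compound 3 `O=C(/C(=C\c1ccc(Cl)c([N+](=O)[O-])c1)S(=O)(=O)c1ccc(Br)cc1)c1ccc(Br)cc1` then replaces. Compound 3 carries 4-chloro-3-nitrophenyl in place of 2-fluoro-4-methoxyphenyl on a double-bonded chain carbon bound to a double-bonded chain carbon. Among the compounds with values here, no measured compound carries chloro or nitro on this ring, so the direction stays open. A step of modest size in either direction is expected, and the central expectation lies within the scatter. The estimated step is a 1.3-fold lower number from compound 2 to compound 3 (0.10 log units; within the scatter). Compound 3 is estimated at 8000 nM, with an expected range of 2000 nM to 30000 nM.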

Compound 3, concentration for 50% growth inhibition: 10000 nM
Compound 3: the middle estimate sits 1.3-fold (0.10 log units) below what was measured; measured number inside the range.
By their numbers in this assay, from the lowest: compounds 2 and 3 (each within the scatter of the next); then compound 1.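

In this assay, changing the ring on a double-bonded chain carbon bound to a double-bonded chain carbon gives no change at the digits printed from compound 2 to compound 3 (within the scatter), so this position accepts 4-chloro-3-nitrophenyl as well as 2-fluoro-4-methoxyphenyl. Measured against the unfluorinated ring, the same group gives a 2.5-fold lower number from compound 1 to compound 3 (0.40 log units; beyond the scatter), which shows that neither methoxy nor fluoro is needed on this ring to reach the level of compound 2. No measurement on hand accounts for either step.

Chloro and nitro enter together in compound 3, so what each contributes alone remains unresolved. Also open, going by these compounds, is how this position responds to a ring bearing an amine or a carboxylic acid, and whether any such group moves the number further than the steps seen so far.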